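This account rests on a few compounds, and the source may have more. Where it says the series, first, only, none or still open, it means among the compounds named here.

Measured so far in an ADME assay on cells for inhibition of cytochrome P450 11B1, mitochondrial (Homo sapiens), read by HPLC, with a stated time of 60 min; a lower number here means a stronger inhibitor, a higher number a weaker inhibitor:
Compound 1 `Fc1ccc2nc(-n3ccnn3)n(C3CC3)c2c1` gives 9070 nM.
Compound 2 `Fc1ccc2nc(-c3cccnn3)n(C3CC3)c2c1` gives > 10000 nM, which is a limit of the assay, not a number.
Compound 3 `Fc1cc2nc(-c3cncnc3C3CC3)n(C3CC3)c2cc1F` gives > 10000 nM, likewise a limit of the assay.

Going by the values given here, the only step between measured neighbours, an at least 1.1-fold higher number from compound 1 to compound 2 (0.04 log units; that floor lies within the scatter), runs from a number to a limit, so its floor is all that is known. With the limit of > 10000 nM in this assay, at which 2 of the 3 values shown sit, the two limits cannot be ranked against each other. Compound 3 therefore stands at the weak end of what this assay can record, with no number of its own.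

Compound 4 `Fc1cc2nc(-c3cncnc3C(F)F)n(C3CC3)c2cc1F` differs from compound 3 by difluoromethyl in place of cyclopropyl on an aromatic carbon. Among the compounds with values here, none of the measured steps bears on this exchange; the one step available concerns a different group on a different core, and it did not itself leave the scatter. No direction can be taken from it.

The value of compound 4 in this assay is thus expected to stay near the limit where compound 3 sits, with the step that the limit leaves unreadable from compound 3 to compound 4 expected to be none beyond the scatter. For compound 4 the estimate is 15000 nM, with a range from 5000 nM to 50000 nM, and a limit rather than a number remains the likeliest outcome.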

Compound 4, half-maximal inhibitory concentration: 4330 nM
Compound 4: middle estimate off by 3.5-fold (0.54 log units), on the high side; the whole stated range lies above it.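

In this assay, difluoromethyl in place of cyclopropyl on an aromatic carbon, next to the ring nitrogen and ortho to a large group, gives an at least 2.3-fold lower number from compound 3 to compound 4 (0.36 log units; beyond the scatter). This is the first step in the series shown to leave the scatter, so this position on the six-membered aromatic ring with 2 nitrogen can bring a compound off the limit and onto a readable number. The true size of the step stays unknown, and only its floor can be read: the limit of > 10000 nM in this assay, at which 2 of the 4 values shown sit.

As far as these compounds go, whether the fluorine atoms or the loss of the three-membered ring carries the step stays open. Also open, from the compounds shown here alone, is how a methyl, a trifluoromethyl or a methoxy group would read at this position, and whether an amine there would move the number further.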